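The source may hold more compounds than are shown below. What is called first, only, known or untested is meant among the compounds shown, and "the series" means these compounds.

Compound 1 `Oc1ccccc1/C=N/c1nnc(SCc2nnc(-c3ccccc3)o2)s1` and compound 2 `Oc1ccccc1/C=N/c1nnc(SCc2nnc(-c3ccc(F)cc3)o2)s1` share one core and differ only in the ring at the far end of the chain. In a functional assay on A549 cells (Homo sapiens) for inhibition, read by CCK-8 assay (a higher number here means a weaker inhibitor, a lower number a stronger inhibitor), compound 1 gives 4110 nM, while compound 2 gives 20100 nM. Within the data shown here, compound 2 thus has the higher of the two numbers and is the weaker inhibitor; the one measured step, a 4.9-fold higher number from compound 1 to compound 2 (0.69 log units; beyond the scatter), shows that a fluorine added to the phenyl ring went with weaker inhibition. Compound 3 `Oc1ccccc1/C=N/c1nnc(SCc2nnc(-c3ccccc3Cl)o2)s1` carries the change (2-chlorophenyl in place of 4-fluorophenyl on an aromatic carbon). Among the measured compounds shown here, no measured step covers a chlorine in this position, so the only guide is that one modest step. A number near that of compound 2, perhaps somewhat lower, is expected for compound 3, so that the expected step of a 2.0-fold lower number from compound 2 to compound 3 (0.30 log units; within the scatter) stays within the scatter. The estimate for compound 3 in this assay is 10000 nM, with a range from 3000 nM to 35000 nM.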

Compound 3, half-maximal inhibitory concentration: 18100 nM
For compound 3 the middle estimate is 1.8-fold (0.26 log units) below the measured one, and the stated range covers the measured number.
By their numbers in this assay, from the lowest: compound 1; then compounds 3 and 2 (each within the scatter of the next).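

In this assay, replacing 4-fluorophenyl with 2-chlorophenyl makes no clear difference: a 1.1-fold lower number from compound 2 to compound 3 (0.05 log units; within the scatter) leaves the two compounds indistinguishable. The chlorine-bearing ring also stands apart from the plain phenyl ring, with a 4.4-fold higher number from compound 1 to compound 3 (0.64 log units; beyond the scatter), so among these three compounds, compound 1 is the strongest inhibitor and both halogen-bearing rings go with weaker inhibition. No supporting data are available to explain why these two rings give such similar results.

The two halogens differ both in identity and in their place on the ring, so these compounds cannot show which of those two changes matters, or whether either one does. On these data alone, it also remains open whether a methoxy group, an amine or a carboxylic acid on this phenyl ring would likewise go with weaker inhibition.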